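This account rests on a few compounds, and the source may have more. Where it says the series, first, only, none or still open, it means among the compounds named here.

Series notes on the shared core of compound 1 `FC(F)(F)c1cc(NC[C@H]2CCCN2)c2cn[nH]c2c1`. In an assay for inhibition of Indoleamine 2,3-dioxygenase 1 (Homo sapiens), with stated times of 10 min and 60 min, tested at 10 uM (on this read-out lower numbers stand for a weaker effect and higher numbers for a stronger effect at the one concentration tested), compound 1 gives 34%; compound 2 `O=[N+]([O-])c1ccccc1CNc1cccc2[nH]ncc12` gives 25% in this assay, and the gap between the two lies within the usual scatter. Among the measured compounds shown here, no step between measured compounds is available. Compound 3 `FC(F)(F)c1cc(NCc2cccc(Br)c2)c2cn[nH]c2c1` differs from compound 1 by 3-bromophenyl in place of pyrrolidin-2-yl on a saturated chain carbon bound to a nitrogen on an aromatic ring. Without a measured step of this kind, no change beyond the scatter is expected, and the step of a number 6 percentage points lower from compound 1 to compound 3 (within the scatter) is an estimate only. For compound 3 the expected value in this assay is 28%, within 10% to 50%.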

Compound 3, a percentage reported as inhibition, at one concentration (the size of the read-out at that concentration, not a potency): 23%
Compound 3: middle estimate off by 5 percentage points, on the high side, within the range that was stated.
By their numbers in this assay, from the lowest: compounds 3, 2 and 1 (each within the scatter of the next, the first and the last beyond it).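

In this assay, among the compounds shown here, the exchange of pyrrolidin-2-yl for 3-bromophenyl on a saturated chain carbon bound to a nitrogen on an aromatic ring gives the first readable step, a number 11 percentage points lower from compound 1 to compound 3 (beyond the scatter), so the group at this place can shift the read-out, though modestly. The exchange alters several things at once, including the ring type, the hydrogen-bond donor and acceptor counts and the defined stereocentre. No measured evidence links the step to any one of these.

Still open, on these data alone, is whether the step follows from the loss of the pyrrolidine amine or from the entry of the bromophenyl ring. An open-chain amine such as dimethylaminoethyl, or an unsubstituted phenyl, at this place would help separate the two.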